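The source may report more compounds than this note shows. Statements on the series, on what has been measured and on what is new or still open speak of the compounds shown alone.

Of the compounds shown here, two built on one shared core have been measured so far. Compound 1 `Cc1cc(=O)n(-c2ccccc2OC(F)(F)F)nc1C(=O)Nc1ccc(Oc2ncnc3ccsc23)cc1` gives 10100 nM in a functional assay on A549 cells (Homo sapiens) for cytotoxicity, read by MTT assay, with a stated time of 72 h; a higher number here means a weaker inhibitor, a lower number a stronger inhibitor. Compound 2 `Cc1cc(=O)n(-c2ccc(F)cc2)nc1C(=O)Nc1ccc(Oc2ncnc3ccsc23)cc1` gives 2360 nM in this assay, the lowest of the two numbers, and the step of a 4.3-fold lower number from compound 1 to compound 2 (0.63 log units; beyond the scatter) is a modest shift brought by exchanging the whole ring on the aromatic nitrogen. Compound 3 `Cc1cc(=O)n(-c2ccc(F)c(F)c2)nc1C(=O)Nc1ccc(Oc2ncnc3ccsc23)cc1` has not been measured. It differs from compound 2 by fluoro in place of hydrogen on an aromatic carbon, so that 4-fluorophenyl becomes 3,4-difluorophenyl. Going by the values given here, no measured step bears directly on this change: the only step known swaps one whole aromatic substituent for another and cannot show what one added fluoro does on a ring that already carries fluoro. With nothing pointing either way, the expected step of a 1.1-fold lower number from compound 2 to compound 3 (0.03 log units; within the scatter) is one that stays within the usual scatter. Compound 3 is therefore estimated to give 2200 nM in this assay, with a range from 800 nM to 6500 nM.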

Compound 3, half-maximal inhibitory concentration: 8180 nM
The estimate for compound 3 lay 3.7-fold (0.57 log units) below the measured number; measured number outside the range, above it.
By their numbers in this assay, from the lowest: compound 2; then compounds 3 and 1 (each within the scatter of the next).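

In this assay, the change from 4-fluorophenyl to 3,4-difluorophenyl is not a silent one (a 3.5-fold higher number from compound 2 to compound 3 (0.54 log units; beyond the scatter)). This shows that the ring carbon ortho to a fluoro group responds to a single added fluorine, a change of just one heavy atom, whereas the earlier step replaced a whole aromatic substituent. That one fluoro also leaves compound 3 level with compound 1 (a 1.2-fold lower number from compound 1 to compound 3 (0.09 log units; within the scatter)), even though the two rings carry different groups, and no measurement shown here explains these results.

On these data alone, whether chloro, methoxy or an amine at this same ring carbon would give a step of similar size remains open. Also open, as far as these compounds go, is whether the added fluoro would have the same effect on a phenyl ring carrying no other fluoro.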